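Replacing the Benzyl Group on the Ring Nitrogen

The compounds below may be only part of what the source reports. "The series", "measured", "known", "first", "only" and "open" are said of these compounds alone.

In an ADME assay on the whole organism (Rattus norvegicus, strain Sprague-Dawley) for pharmacokinetics, read by LC-MS, at a dose of 5 mg/kg by the oral route (on this read-out lower numbers stand for lower exposure and higher numbers for higher exposure at the dose given), compound 2 `Cc1cccc(F)c1CN1CCc2cc(-c3c(C)nc(C)c([C@H](OC(C)(C)C)C(=O)O)c3N3CCC(C)(C)CC3)ccc2C1` gives 9630 ng.h/mL. Compound 1 `Cc1cccc(Cl)c1CN1CCc2cc(-c3c(C)nc(C)c([C@H](OC(C)(C)C)C(=O)O)c3N3CCC(C)(C)CC3)ccc2C1` gives 9210 ng.h/mL, and compound 3 `Cc1nc(C)c([C@H](OC(C)(C)C)C(=O)O)c(N2CCC(C)(C)CC2)c1-c1ccc2c(c1)CCN(Cc1cccc(F)c1F)C2` gives 5090 ng.h/mL. Compound 2 therefore stands within the scatter of both others, with a 1.0-fold higher number from compound 1 to compound 2 (0.02 log units; within the scatter) and a 1.9-fold lower number from compound 2 to compound 3 (0.28 log units; within the scatter), while the remaining pair shows a 1.8-fold lower number from compound 1 to compound 3 (0.26 log units; within the scatter).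

Compound 4 `Cc1nc(C)c([C@H](OC(C)(C)C)C(=O)O)c(N2CCC(C)(C)CC2)c1-c1ccc2c(c1)CCN(c1nccc(-c3cnccn3)n1)C2` departs from compound 2 at one place: a group of 12 heavy atoms (8 carbon, 4 nitrogen; 2 six-membered aromatic rings with 2 hetero atoms each) in place of a group of 9 heavy atoms (8 carbon, 1 fluorine; one six-membered aromatic ring of carbon only), on an amine nitrogen in a ring. The measured steps bear on this only indirectly. Within the data shown here, they exchange one substituted benzyl group for another, and no measured compound carries the entering group, so the data hold no step of this kind. Even the larger exchange, a 1.9-fold lower number from compound 2 to compound 3 (0.28 log units; within the scatter), stays within the scatter and sets no firm direction. A change this large could still move exposure well beyond that scatter, and a moderate fall is tentatively expected. The estimated step is a 2.4-fold lower number from compound 2 to compound 4 (0.38 log units; beyond the scatter). For compound 4 the estimated value is 4000 ng.h/mL, with an expected range of 1000 ng.h/mL to 14000 ng.h/mL.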

Compound 4, area under the concentration-time curve: 15100 ng.h/mL
For compound 4 the middle estimate is 3.8-fold (0.58 log units) below the measured one; the whole stated range lies below it.
By their numbers in this assay, from the lowest: compounds 3, 1, 2 and 4 (each within the scatter of the next, the first and the last beyond it).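

In this assay the amine nitrogen in the ring tolerates far more than a swap of one substituted benzyl group for another: the entering group, with two aromatic rings that each hold two hetero atoms, gives a 1.6-fold higher number from compound 2 to compound 4 (0.20 log units; within the scatter) and a 1.6-fold higher number from compound 1 to compound 4 (0.21 log units; within the scatter) and so stays level with the two ortho-free... 

Correction, final text:

In this assay the amine nitrogen in the ring accepts much more than an exchange of one substituted benzyl group for another, since the entering group, with its two aromatic rings holding two hetero atoms each, shows a 1.6-fold higher number from compound 2 to compound 4 (0.20 log units; within the scatter) and a 1.6-fold higher number from compound 1 to compound 4 (0.21 log units; within the scatter) and so loses no exposure against either benzyl compound. Among these compounds, only one step now clears the scatter, a 3.0-fold higher number from compound 3 to compound 4 (0.47 log units; beyond the scatter), and it is the first step to do so. Nothing in hand accounts for this result.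

The compounds shown leave open whether a single aromatic ring on that nitrogen would serve as well as the pair. They also leave open how an acetyl group or a methylsulfonyl group on the same nitrogen would fare in exposure.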